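A Piperidinylmethyl Group on Two Fluorinated Benzophenone Cores

A few compounds are considered here, and "the series" means these few. Any claim that something is new, unique, unknown or untested is made for them only; others in the source may bear on it.

Measured compounds:
compound 1 `COc1cc(O)c(C(=O)c2cccc(F)c2)c(OC)c1`: 81%
compound 2 `COc1cc(OC)c(C(=O)c2cccc(F)c2)c(O)c1CN1CCCCC1`: 87%
compound 3 `COc1cc(O)c(C(=O)c2ccccc2F)c(OC)c1`: 71%

All three were tested in a functional assay on THP-1 cells (Homo sapiens) for inhibition, read by ELISA, with stated times of 30 min and 24 h, tested at 10 uM; a higher number here means a stronger effect of the compound at the concentration tested, a lower number a weaker effect. Compound 2 differs from compound 1 by (piperidin-1-yl)methyl in place of hydrogen on an aromatic carbon; the step of a number 6 percentage points higher from compound 1 to compound 2 (within the scatter) shows how little this change moved the read-out. Compound 3 shares its atoms with compound 1 but joins them differently; the difference between the two cores is not broken down here. In this assay compound 3 gives 71%, and compound 1 gives 81%, a gap within the scatter.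

Compound 4 `COc1cc(OC)c(C(=O)c2ccccc2F)c(O)c1CN1CCCCC1` has not yet been measured. It differs from compound 3 by (piperidin-1-yl)methyl in place of hydrogen on an aromatic carbon. This is the same kind of change as from compound 1 to compound 2, though here the new group sits meta to a (2-fluorophenyl)carbonyl group rather than meta to a (3-fluorophenyl)carbonyl group.

Because the earlier step of a number 6 percentage points higher from compound 1 to compound 2 (within the scatter) stayed within the scatter, the step of a number 6 percentage points higher from compound 3 to compound 4 (within the scatter) is expected to be of similar size. Compound 4 is therefore estimated to give 77%, within a range from 62% to 90%.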

Compound 4, a percentage reported as activity, at one concentration (the size of the read-out at that concentration, not a potency): 84%
Compound 4: middle estimate off by 7 percentage points, on the low side, and the stated range covers the measured number.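

Adding the (piperidin-1-yl)methyl group to the second core gives a number 13 percentage points higher from compound 3 to compound 4 (beyond the scatter) in this assay, while with that group present, 2-fluorophenyl in place of 3-fluorophenyl gives a number 3 percentage points lower from compound 2 to compound 4 (within the scatter). Although only the second step on the two cores passes the scatter, the two steps cannot be told apart: the same change on two cores in this assay, a number 6 percentage points higher (within the scatter) from compound 1 to compound 2 and a number 13 percentage points higher (beyond the scatter) from compound 3 to compound 4, 7 percentage points apart, within the scatter of two such steps So the change carried over between these two closely related cores at a similar size, but two pairs cannot show that it would do so on other cores, and they do not explain why it behaves this way.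

The compounds shown leave open whether another amine, such as morpholine or dimethylamine, would behave like piperidine. They also leave open what a longer chain between the ring and the nitrogen would do.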